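The source may hold more compounds than are shown below. What is called first, only, known or untested is meant among the compounds shown, and "the series" means these compounds.

Measured in an assay on mitochondria for inhibition of Amine oxidase [flavin-containing] B (Rattus norvegicus); a lower number here means a stronger inhibitor, a higher number a weaker inhibitor:
compound 1, `NC(=O)[C@H](CO)NCc1ccc(OCc2ccc(Cl)cc2)cc1`: 1100 nM
compound 2, `NC(=O)[C@@H](NCc1ccc(OCc2cccc(Cl)c2)cc1)c1ccccc1`: 10100 nM
compound 3, `NC(=O)[C@@H](NCc1ccc(OCc2ccccc2)cc1)c1ccccc1`: 73800 nM

Compound 2 stands second highest of the three numbers, between compound 1 and compound 3. Compound 4, `NC(=O)[C@H](CO)NCc1ccc(OCc2cccc(Cl)c2)cc1`, differs from compound 2 by hydroxymethyl in place of phenyl on a saturated chain carbon bound to an amine nitrogen and a carbonyl carbon. For the measured compounds named here, no measured step covers this exchange: the only one-place step known, a 7.3-fold higher number from compound 2 to compound 3 (0.86 log units; beyond the scatter), concerns hydrogen in place of chloro on an aromatic carbon. Compound 1 carries the same hydroxymethyl group and shows a lower number than compound 2, though the two also differ in the placing of the chloro, so this is a hint rather than a step. On that hint, compound 4 is expected to give a lower number, a 6.7-fold lower number from compound 2 to compound 4 (0.83 log units; beyond the scatter). Compound 4 is estimated at 1500 nM, within 400 nM to 6000 nM.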

Compound 4, half-maximal inhibitory concentration: 43 nM
Beside the measured number, compound 4's estimate is 35-fold (1.54 log units) above it; the whole stated range lies above it.
By their numbers in this assay, from the lowest: compound 4; then compound 1; then compound 2; then compound 3.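

In this assay, the chain carbon bound to an amine nitrogen and a carbonyl carbon proves highly sensitive, with hydroxymethyl in place of phenyl giving a large change (a 230-fold lower number from compound 2 to compound 4 (2.37 log units; beyond the scatter)). The placing of the chloro also matters when hydroxymethyl is present, as 3-chlorophenyl in place of 4-chlorophenyl gives another large change (a 26-fold lower number from compound 1 to compound 4 (1.41 log units; beyond the scatter)). No evidence is available to explain either change. As far as these compounds go, whether an amine or a longer chain on that carbon would keep the number low remains open. So does whether the chloro placing matters as much with phenyl on that carbon.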